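The source may report more compounds than this note shows. Statements on the series, on what has been measured and on what is new or still open speak of the compounds shown alone.

In a functional assay for inhibition, with Homo sapiens as the target (a lower number here means a stronger inhibitor, a higher number a weaker inhibitor), compound 1 `CCCCS(=O)(=O)N[C@@H](CNC(=O)c1ccc2c(c1)C(=O)N(CCC1CCNCC1)C2)C(=O)O` gives 14 nM; 9 nM (2 entries), and compound 2 `O=C(NC[C@H](NS(=O)(=O)Cc1ccccc1)C(=O)O)c1ccc2c(c1)C(=O)N(CCC1CCNCC1)C2` gives 4 nM. Among the measured compounds shown here, that is the only number for compound 2, whose one further entry carries no single number. Compound 3 `O=C(NC[C@H](NS(=O)(=O)c1ccccc1C(=O)O)C(=O)O)c1ccc2c(c1)C(=O)N(CCC1CCNCC1)C2` keeps the shared core but has 2-carboxyphenyl in place of benzyl on a sulfonyl sulfur. For the measured compounds named here, no measured step between these compounds shows what such a swap does. A modest move towards weaker inhibition is expected, only slightly beyond the usual scatter, and the estimated change is a 2.5-fold higher number from compound 2 to compound 3 (0.40 log units; beyond the scatter). For compound 3 the expected value is 10 nM, with an estimated range of 3 nM to 40 nM.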

Compound 3, half-maximal inhibitory concentration: 15 nM
Compound 3: the middle estimate sits 1.5-fold (0.18 log units) below what was measured, within the range that was stated.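

In this assay, 2-carboxyphenyl in place of benzyl on a sulfonyl sulfur gives a 3.8-fold higher number from compound 2 to compound 3 (0.57 log units; beyond the scatter), so this position tolerates the new group at a modest cost in inhibition. The swap removes the benzyl chain carbon and adds a carboxylic acid at once, so this single step cannot separate the two changes. Repeat entries show how far one compound's numbers can move on their own: the several entries of compound 1 in this assay, 14 nM; 9 nM (2 entries).

Still open, from the compounds shown here alone, is whether plain phenyl, or a phenyl ring carrying an amine instead of the carboxylic acid, would behave more like benzyl or like 2-carboxyphenyl.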